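The source may report more compounds than this note shows. Statements on the series, on what has been measured and on what is new or still open speak of the compounds shown alone.

Compound 1, `O=C(COc1ccc2cc(/C=C3/SC(=O)NC3=O)ccc2c1)Nc1ccc(Br)cc1F`, gives 1900 nM in an assay on isolated protein for inhibition of histone deacetylase 4 (Homo sapiens), with a stated time of 1 h; on this read-out higher numbers stand for weaker inhibition and lower numbers for stronger inhibition.
Compound 2, `O=C(COc1ccc2cc(/C=C3/SC(=O)NC3=O)ccc2c1)Nc1cccc(C(F)(F)F)c1`, gives 2500 nM in this assay.

Within the data shown here, of the two numbers measured so far in this assay, that of compound 2 is the larger, but the only recorded step, a 1.3-fold higher number from compound 1 to compound 2 (0.12 log units; within the scatter), lies within the scatter, so compound 1 and compound 2 cannot be told apart on this read-out. Compound 3, `O=C(COc1ccc2cc(/C=C3/SC(=O)NC3=O)ccc2c1)Nc1ccc([N+](=O)[O-])cc1`, is reached from compound 2 by a change at the same position: 4-nitrophenyl in place of 3-(trifluoromethyl)phenyl on an amide-type nitrogen. Among the measured compounds shown here, the one step that bears on this position, a 1.3-fold higher number from compound 1 to compound 2 (0.12 log units; within the scatter), swapped one substituted phenyl on the amide nitrogen for another without a change beyond the scatter; nothing measured so far speaks to a nitro group in particular. On that basis compound 3 is expected to stay close to compound 2, with a step of no change at the digits printed from compound 2 to compound 3 (within the scatter). The estimated value for compound 3 is 2500 nM, with a likely range from 1000 nM to 6500 nM.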

Compound 3, half-maximal inhibitory concentration: 1700 nM
Beside the measured number, compound 3's estimate is 1.5-fold (0.17 log units) above it, and the stated range covers the measured number.
By their numbers in this assay, from the lowest: compounds 3, 1 and 2 (each within the scatter of the next).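

In this assay a third substituted phenyl group on the amide-type nitrogen again leaves the read-out unresolved: a 1.5-fold lower number from compound 2 to compound 3 (0.17 log units; within the scatter) and a 1.1-fold lower number from compound 1 to compound 3 (0.05 log units; within the scatter) both lie within the scatter. The change from 3-(trifluoromethyl)phenyl, which has no hydrogen-bond acceptors, to 4-nitrophenyl, which has them, thus gives no measurable difference, and compound 1, compound 2 and compound 3 cannot be told apart on this read-out. The data shown offer no explanation for this flat result.

On these data alone, all three compounds keep a substituted phenyl ring at this position, so it remains open whether the number would move beyond the scatter with an amine or a carboxylic acid on that ring. As far as these compounds go, it is equally open whether replacing the ring with a longer alkyl chain would do so.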